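The source may report more compounds than this note shows. Statements on the series, on what has been measured and on what is new or still open speak of the compounds shown alone.

Measured so far:
compound 1, `COCCn1c(-c2ccccc2Cl)nc2c(N3CCN(C(C)=O)CC3)nc(C)nc21`: 95%
compound 2, `Cc1nc(N2CCN(C)CC2)c2nc(-c3cccc(Cl)c3)n(C3CCOCC3)c2n1`: 45%

In an ADME assay (liver) for metabolic stability, with Liver microsome (Rattus norvegicus) as the target, read by LC-MS, using microsomes, with a stated time of 30 min, tested at 4 uM (a lower number here means that less of the compound is left, a higher number that more of the compound is left), compound 1 gives 95%, while compound 2 gives 45%. Compound 2 thus holds the lower of the two numbers seen so far, and its distance to compound 1 lies beyond the usual scatter of this assay. Within the data shown here, the two compounds differ in more than one place, so no single step between them can be read off.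

The account therefore follows the move from compound 2 to compound 3, `COc1ccc(-c2nc3c(N4CCN(C)CC4)nc(C)nc3n2C2CCOCC2)c(C)c1`, which has not yet been tested. The change is 4-methoxy-2-methylphenyl in place of 3-chlorophenyl on an aromatic carbon.

Among the measured compounds shown here, with only two measured numbers and no step between them, there is little to lean on. Since compound 2 already sits low in this assay, the room for a further fall is limited, and a small downward step or none beyond the scatter is expected. Compound 3 is therefore estimated at 32%, with a range from 10% to 58%. That estimate means an expected step of a number 13 percentage points lower from compound 2 to compound 3 (beyond the scatter).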

Compound 3, percent of the compound remaining: 24%
Beside the measured number, compound 3's estimate is 8 percentage points above it; low and high end bracket the measured number.
By their numbers in this assay, from the lowest: compound 3; then compound 2; then compound 1.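

In this assay, among these compounds, placing 4-methoxy-2-methylphenyl in place of 3-chlorophenyl on the aromatic carbon next to the ring atom that bears an oxan-4-yl group gives a number 21 percentage points lower from compound 2 to compound 3 (beyond the scatter) and is the first change here that can be read in one place. It shows that the number responds to the aryl group at this position even when the rest of the molecule stays the same, and that this exchange leaves less of the compound after the stated incubation. Nothing at hand explains the fall.

The single step changes several things at once, removing the chlorine and adding both methoxy and methyl, so the compounds shown leave open which of these carries the step, and a plain phenyl, a 4-methoxyphenyl or a 2-methylphenyl at this place would be needed to separate them. Steps to compound 1 cannot be read, as it differs from the others in more than one place, so it remains open how the aryl group acts alongside a 2-methoxyethyl chain or an acetyl group on the piperazine.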